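The source may hold more compounds than are shown below. What is called first, only, known or untested is meant among the compounds shown, and "the series" means these compounds.

The measured compounds:
Compound 1, `COc1ccccc1CNc1nc2c(N)ncnc2n1[C@@H]1O[C@H](CO)[C@@H](O)[C@H]1O`, in an assay on COS-7 cells for inhibition of sodium/nucleoside cotransporter 2 (Homo sapiens), read by scintillation counting, in the presence of a further agent that is not named here (a higher number here means a weaker inhibitor, a lower number a stronger inhibitor), gives a result that is a limit of the assay and not a number: > 100000 nM.
Compound 2, `Nc1ncnc2c1nc(NCc1cccc(Cl)c1)n2[C@@H]1O[C@H](CO)[C@@H](O)[C@H]1O`, in this assay gives 5400 nM.
Compound 3, `Nc1ncnc2c1nc(NCc1ccccc1Cl)n2[C@@H]1O[C@H](CO)[C@@H](O)[C@H]1O`, in this assay gives 5700 nM.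

Compound 3 stands at the higher of the two numbers available, its nearest neighbour being compound 2 (a 1.1-fold higher number from compound 2 to compound 3 (0.02 log units; within the scatter)), while compound 1 sits at a limit (the limit of > 100000 nM in this assay, at which 1 of the 3 values shown sits). Compound 4, `Nc1ncnc2c1nc(NCc1ccc3ccccc3c1)n2[C@@H]1O[C@H](CO)[C@@H](O)[C@H]1O`, is not yet measured. It differs from compound 3 in one place: naphthalen-2-yl in place of 2-chlorophenyl on a saturated chain carbon bound to a nitrogen on an aromatic ring. Within the data shown here, of the measured steps, the one most like it swaps one group on the same saturated chain carbon for another, a 1.1-fold higher number from compound 2 to compound 3 (0.02 log units; within the scatter), and lies within the scatter. The two steps that leave compound 1, an at least 18-fold lower number from compound 1 to compound 2 (1.26 log units; beyond the scatter) and an at least 17-fold lower number from compound 1 to compound 3 (1.24 log units; beyond the scatter), are large, but both concern chloro against methoxy, not the change to naphthalen-2-yl. Among the measured compounds shown here, no measured step covers that change, so the expectation rests on compound 3 alone and is held loosely. Compound 4 is estimated at 4500 nM, expected to fall between 1000 nM and 25000 nM. The step that this estimate implies, a 1.3-fold lower number from compound 3 to compound 4 (0.10 log units; within the scatter), is expected to stay within the scatter.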

Compound 4, half-maximal inhibitory concentration: 5300 nM
Compound 4: the middle estimate sits 1.2-fold (0.07 log units) below what was measured; low and high end bracket the measured number.
By their numbers in this assay, from the lowest: compounds 4, 2 and 3 (each within the scatter of the next). At a limit, above all of these: compound 1.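

Compound 4 shows that this position, on a saturated chain carbon bound to a nitrogen on an aromatic ring, accepts a larger group of 2 six-membered aromatic rings and no chlorine without a change that can be told apart in this assay: a 1.1-fold lower number from compound 3 to compound 4 (0.03 log units; within the scatter), and a 1.0-fold lower number from compound 2 to compound 4 (0.01 log units; within the scatter). The earlier compounds had shown only that 2-chlorophenyl and 3-chlorophenyl could not be told apart, so chlorine is now seen not to be required here, and the group can go from 7 to 10 heavy atoms with the number staying within the scatter. Against these three compounds stands compound 1 alone, with an at least 18-fold lower number from compound 1 to compound 4 (1.27 log units; beyond the scatter), and its value is a limit of the assay and not a number: the limit of > 100000 nM in this assay, at which 1 of the 4 values shown sits.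

The compounds shown leave open whether the loss in compound 1 belongs to the methoxy group itself or to its place on the ring, since no 3-methoxyphenyl group appears among them. They also leave open how an amine or a carboxylic acid on the ring, or a longer chain in place of the single saturated chain carbon, would read in this assay.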